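From phenyl to 2,4-dimethoxyphenyl on compound 1

The compounds below may be only part of what the source reports. "The series", "measured", "known", "first", "only" and "open" are said of these compounds alone.

Compound 1 `O=C(Nc1ccccc1)c1cc2cnc(Nc3ccc(N4CCNCC4)cn3)nc2n1C1CCCC1` gives 5120 nM
Compound 2 `COc1ccc(NC(=O)c2cc3cnc(Nc4ccc(N5CCNCC5)cn4)nc3n2C2CCCC2)cc1` gives 8970 nM

Among the compounds with values here, in a functional assay on BXPC-3 cells (Homo sapiens) for inhibition, read by MTT assay (a higher number here means a weaker inhibitor, a lower number a stronger inhibitor), compound 1 is one of only two measured compounds, and compound 2 lies within the scatter of it. The unmeasured compound 3 `COc1ccc(NC(=O)c2cc3cnc(Nc4ccc(N5CCNCC5)cn4)nc3n2C2CCCC2)c(OC)c1` differs from compound 1 by one change: 2,4-dimethoxyphenyl in place of phenyl on an amide-type nitrogen while the shared core stays the same. Within the data shown here, the only measured step that bears on this is a 1.8-fold higher number from compound 1 to compound 2 (0.24 log units; within the scatter) for methoxy in place of hydrogen on an aromatic carbon. Among the measured compounds shown here, compound 3 carries two methoxy groups, and no measured compound shows what the two do together. In this assay a small move toward a higher number is therefore expected, possibly none beyond the scatter. The expected step is a 1.7-fold higher number from compound 1 to compound 3 (0.22 log units; within the scatter) on this estimate. Compound 3 is estimated at 8500 nM and expected to fall between 3000 nM and 22000 nM.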

Compound 3, half-maximal inhibitory concentration: 3650 nM
For compound 3 the middle estimate is 2.3-fold (0.37 log units) above the measured one; measured number inside the range.
By their numbers in this assay, from the lowest: compounds 3, 1 and 2 (each within the scatter of the next, the first and the last beyond it).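

In this assay, 2,4-dimethoxyphenyl in place of phenyl on the amide-type nitrogen gives a 1.4-fold lower number from compound 1 to compound 3 (0.15 log units; within the scatter) and so leaves the number inside the usual scatter, even though the new group is larger and brings two methoxy groups. The clearer signal comes from adding the second methoxy group, which gives a 2.5-fold lower number from compound 2 to compound 3 (0.39 log units; beyond the scatter) as a modest step, while the first methoxy group gave a 1.8-fold higher number from compound 1 to compound 2 (0.24 log units; within the scatter) and so the same kind of change does not read the same on compound 1 and on compound 2. Nothing measured here explains this difference between the two methoxy steps.

Open, from the compounds shown here alone, is whether the second methoxy group would give the same step on phenyl without the first. Also open, going by these compounds, is how a hydroxyl, a fluorine or a carboxylic acid in place of methoxy would read in this assay on the shared core.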